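Acetyl in Place of Acetyl(methyl)amino: An Expected Potency

The source may report more compounds than this note shows. Statements on the series, on what has been measured and on what is new or still open speak of the compounds shown alone.

Measured so far:
compound 1, `CC(=O)N(C)c1ccc(Sc2ncc([C@]3(C)COC(C)(C)O3)s2)cc1`: 6210 nM
compound 2, `CC(=O)N(C)c1ccc(Sc2ncc([C@@]3(C)COC(C)(C)O3)s2)cc1`: 70 nM

Within the data shown here, in a functional assay on blood for inhibition of Polyunsaturated fatty acid 5-lipoxygenase (Homo sapiens) (a higher number here means a weaker inhibitor, a lower number a stronger inhibitor), compound 2 gives 70 nM, the lowest of the two numbers so far. Among the measured compounds shown here, its only neighbour is compound 1, which gives 6210 nM. For the measured compounds named here, the one measured step, an 89-fold lower number from compound 1 to compound 2 (1.95 log units; beyond the scatter), is a large one, and it rests on the fact that compounds 1 and 2 differ only in the configuration as drawn: the two compounds are the same set of atoms and bonds, mirrored at a single saturated ring carbon.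

Compound 3, `CC(=O)c1ccc(Sc2ncc([C@@]3(C)COC(C)(C)O3)s2)cc1`, is the next compound to be tested. It differs from compound 2 by acetyl in place of acetyl(methyl)amino on an aromatic carbon. Going by the values given here, no measured step involves this part of the molecule; the single step in hand concerns configuration only, so it offers no guide to whether the new group will raise or lower the number, nor by how much. Among the compounds with values here, with no direct precedent, the expectation is a step of modest size in either direction, a 2.1-fold higher number from compound 2 to compound 3 (0.33 log units; beyond the scatter), kept within a wide range. The estimate for compound 3 in this assay is therefore 150 nM, expected to fall between 30 nM and 800 nM.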

Compound 3, half-maximal inhibitory concentration: 390 nM
Estimate against measurement, compound 3: 2.6-fold (0.41 log units) below, within the range that was stated.
By their numbers in this assay, from the lowest: compound 2; then compound 3; then compound 1.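

In this assay, acetyl in place of acetyl(methyl)amino on an aromatic carbon, para to a large group, gives a 5.6-fold higher number from compound 2 to compound 3 (0.75 log units; beyond the scatter), so the number depends on the group at this position as well as on the configuration of the saturated ring carbon. This step is modest beside an 89-fold lower number from compound 1 to compound 2 (1.95 log units; beyond the scatter), which means that, in these compounds, swapping this group moves the number much less than mirroring that ring carbon does. The leaving and entering groups have the same counts of hydrogen-bond donors and acceptors, and acetyl has fewer heavy atoms and no nitrogen, but nothing measured here explains why the number rises.

The compounds shown leave open whether the rise follows the loss of the nitrogen, the loss of its methyl or the change in the group as a whole, a question that an acetylamino group or a methylamino group at the same place would help to answer. From the compounds shown here alone, it also remains open whether the opposite configuration at the ring carbon would weaken the acetyl compound as strongly as it does the acetyl(methyl)amino pair.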